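Trimming the ethyl on compound 2 to methyl

The compounds below may be only part of what the source reports. "The series", "measured", "known", "first", "only" and "open" are said of these compounds alone.

Measured compounds:
compound 1 `O=C1CC2(CO1)CSC(=S)N2c1ccccc1` with 128000 nM;
compound 2 `CCNC(=S)SCC1=CCOC1=O` with 44400 nM;
compound 3 `CN(C)C(=S)SCC1=CC(=O)OC1` with 7550 nM.

The three compounds were tested in a functional assay on EC9706 cells (Homo sapiens) for antiproliferative activity, read by MTT assay, with a stated time of 72 h; a lower number here means a stronger inhibitor, a higher number a weaker inhibitor. On the numbers shown, compound 2 holds the second highest of the three values. Its nearest neighbour is compound 1, whose value is higher by a margin beyond the scatter; the furthest is compound 3, whose value is lower, again beyond the scatter. Within the data shown here, no step between two measured compounds that differ in a single place is available, so the size of such a step cannot be read from this set.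

The step to be followed leads from compound 2 to compound 4 `CNC(=S)SCC1=CCOC1=O`. The change is hydrogen in place of methyl on a saturated chain carbon bound to an amide-type nitrogen, that is, ethylamino becomes methylamino. Nothing in the measured set shows what loss of one carbon at this place does. Compound 3, which carries two methyl groups on the same nitrogen, gives 7550 nM, but it differs from compound 2 in more than one place, so only the two values can be compared. For compound 4 the expected step of a 1.1-fold lower number from compound 2 to compound 4 (0.05 log units; within the scatter) is none beyond the scatter. Compound 4 is therefore estimated at 40000 nM, with a range from 15000 nM to 110000 nM in this assay.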

Compound 4, half-maximal inhibitory concentration: 85400 nM
Beside the measured number, compound 4's estimate is 2.1-fold (0.33 log units) below it; measured number inside the range.
By their numbers in this assay, from the lowest: compound 3; then compounds 2, 4 and 1 (each within the scatter of the next, the first and the last beyond it).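

In this assay the set now holds its first step between compounds that differ in one place, with ethylamino giving way to methylamino (a 1.9-fold higher number from compound 2 to compound 4 (0.28 log units; within the scatter)). The two values lie within the scatter of each other, so this one step does not separate the two chains, and a methyl on the saturated chain carbon bound to the amide-type nitrogen can be replaced by hydrogen without a difference that repeated measurement could distinguish. No measurement among the data shown bears on this step, and nothing is offered to account for it.

A longer chain such as propyl or butyl on this nitrogen, or a plain amino group with no chain at all, would show whether the same holds further along this series, and the compounds shown do not settle that. Compound 3 at 7550 nM carries two methyl groups on the same nitrogen, but it differs from compound 2 and compound 4 in more than one place, so what the second methyl contributes cannot be read from these compounds.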